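Tetrazole Sulfides and Selenides in a Cell Toxicity Screen

This account rests on a few compounds, and the source may have more. Where it says the series, first, only, none or still open, it means among the compounds named here.

All three measured compounds were tested in an ADME assay on MDCK-II cells (Canis lupus familiaris) for cytotoxicity, read by MTT assay, with a stated time of 48 h; on this read-out lower numbers stand for stronger inhibition and higher numbers for weaker inhibition. Compound 1, `O=[N+]([O-])c1cc(CSc2nnnn2C2CCCCC2)cc([N+](=O)[O-])c1`, reaches no number in this assay: for compound 1 the result is the limit > 30000 nM. Compound 2, `COc1ccc(-n2nnnc2SCc2cc([N+](=O)[O-])cc([N+](=O)[O-])c2)cc1`, carries a 4-methoxyphenyl in place of cyclohexyl on an aromatic nitrogen. For compound 2 the result is again only the limit > 30000 nM. The step between these two, a step that the two limits leave unreadable from compound 1 to compound 2, therefore cannot be sized. For the measured compounds named here, compound 3, `O=[N+]([O-])c1cc(C[Se]c2nnnn2C2CCCCC2)cc([N+](=O)[O-])c1`, is the one compound that gives a number: in this assay compound 3 gives 19000 nM. How the core of compound 3 differs from the core of compound 1 is not broken down here.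

Compound 4, `COc1ccc(-n2nnnc2[Se]Cc2cc([N+](=O)[O-])cc([N+](=O)[O-])c2)cc1`, has not yet been measured. It differs from compound 3 by the same change seen between compound 1 and compound 2, 4-methoxyphenyl in place of cyclohexyl on an aromatic nitrogen, at the same place. Two of the three known values sit at the limit of > 30000 nM in this assay, at which 2 of the 3 values shown sit, so the change has so far left no readable trace. For compound 4 a small expected step is therefore taken, a 1.4-fold higher number from compound 3 to compound 4 (0.14 log units; within the scatter), resting on compound 3 at 19000 nM. Compound 4 is expected to come in near 26000 nM. For compound 4 the expected range runs from 12000 nM to 60000 nM.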

Compound 4, half-maximal inhibitory concentration: < 7500 nM
Compound 4: a limit, no number; the forecaster's own chance of this, stated with the estimate: 45%; middle value at least 3.4-fold (0.53 log units) from the limit.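

In this assay, putting 4-methoxyphenyl in place of cyclohexyl on an aromatic nitrogen gives an at least 2.5-fold lower number from compound 3 to compound 4 (0.40 log units; beyond the scatter), so on the core of compound 3 this change does leave a trace that stands clear of the usual scatter. Compound 4 gives < 7500 nM, which is a limit and not a number, so this shows the direction of the step and only the smallest size it can have. It does not show that the change carries over from one core to the other, because the step on the core of compound 1 cannot be read, with compound 1 and compound 2 both sitting at the same limit: the limit of > 30000 nM in this assay, at which 2 of the 4 values shown sit.

The compounds shown put only cyclohexyl and 4-methoxyphenyl on this nitrogen, so they leave open whether the lower number goes with having an aromatic ring there or with the methoxy group it carries. A plain phenyl would start to separate those two readings, while a longer chain or a ring bearing a carboxylic acid or an amine at that same place would show how far the effect of the group reaches in this series.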